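Benzyl-triazole chromone analogues: from fluorophenyl to cyanophenyl

The source may report more compounds than this note shows. Statements on the series, on what has been measured and on what is new or still open speak of the compounds shown alone.

Compound 1 `O=c1ccoc2cc(OCc3cn(Cc4ccc(Cl)cc4)nn3)ccc12` gives 41700 nM in a functional assay on QGY7701 cells (Homo sapiens) for cytotoxicity, read by MTT assay, with a stated time of 48 h; on this read-out lower numbers stand for stronger inhibition and higher numbers for weaker inhibition.
Compound 2 `O=c1ccoc2cc(OCc3cn(Cc4cccc([N+](=O)[O-])c4)nn3)ccc12` gives 14100 nM in this assay.
Compound 3 `O=c1ccoc2cc(OCc3cn(Cc4ccccc4F)nn3)ccc12` gives 36900 nM in this assay.

Among these three numbers compound 3 sits second highest. Its nearest neighbour is compound 1, the step being a 1.1-fold lower number from compound 1 to compound 3 (0.05 log units; within the scatter), so the two cannot be told apart. Its furthest is compound 2, and that step, a 2.6-fold higher number from compound 2 to compound 3 (0.42 log units; beyond the scatter), lies beyond the scatter.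

The new compound 4 `N#Cc1cccc(Cn2cc(COc3ccc4c(=O)ccoc4c3)nn2)c1` differs from compound 3 in one place: 3-cyanophenyl in place of 2-fluorophenyl on a saturated chain carbon bound to an aromatic nitrogen. Among the measured compounds shown here, two measured steps bear on this. The step of a 2.6-fold higher number from compound 2 to compound 3 (0.42 log units; beyond the scatter) shows that exchanging a 3-nitrophenyl for a 2-fluorophenyl raised the number modestly, and the step of a 3.0-fold lower number from compound 1 to compound 2 (0.47 log units; beyond the scatter) shows a modest drop when 3-nitrophenyl replaced 4-chlorophenyl. For the measured compounds named here, compound 4 carries a 3-cyanophenyl, which, like the nitro group, brings one hydrogen-bond acceptor; no measured pair tests a cyano group directly. The reversed step from compound 2 to compound 3 is the closest guide, so compound 4 is expected to move back toward the number of compound 2, a step of a 1.8-fold lower number from compound 3 to compound 4 (0.27 log units; within the scatter). Compound 4 is therefore estimated at 20000 nM, within a range from 8000 nM to 50000 nM.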

Compound 4, half-maximal inhibitory concentration: 24400 nM
Compound 4: the middle estimate sits 1.2-fold (0.09 log units) below what was measured; low and high end bracket the measured number.
By their numbers in this assay, from the lowest: compounds 2, 4, 3 and 1 (each within the scatter of the next, the first and the last beyond it).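

In this assay, among the compounds shown here, the exchange of cyano for nitro on an aromatic carbon gives the first direct reading on that pair of groups, and the step (a 1.7-fold higher number from compound 2 to compound 4 (0.24 log units; within the scatter)) does not separate 3-cyanophenyl from 3-nitrophenyl. The 3-cyanobenzyl compound also cannot be told apart from the compounds carrying the halogen-bearing rings (a 1.5-fold lower number from compound 3 to compound 4 (0.18 log units; within the scatter); a 1.7-fold lower number from compound 1 to compound 4 (0.23 log units; within the scatter)), so the earlier split between compound 2 on one side and compound 1 and compound 3 on the other now has a compound that falls clearly on neither side. Nothing measured here offers a reason for any of these steps.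

The four compounds all carry a substituted benzyl group on the triazole nitrogen, so they leave open how far this place can shift the number in this assay, given that only compound 2 and compound 1, together with compound 2 and compound 3, stand beyond the scatter of each other. As far as these compounds go, whether an amine or a carboxylic acid on the phenyl ring, or a longer chain in place of the benzyl link, would take the number outside this narrow band also stays open.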